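Swapping a Fluorophenyl for Pyridine on a Weak Inhibitor

The compounds below may be only part of what the source reports. "The series", "measured", "known", "first", "only" and "open" are said of these compounds alone.

Compound 1 `O=C(CN1CCN(c2ccc(F)cn2)CC1)Nc1nc2c(o1)CCCC2` serves as a point of reference: in an assay on isolated protein for inhibition of long-chain fatty acid transport protein 1 (Mus musculus), read by scintillation counting, with a stated time of 20 min (a lower number here means a stronger inhibitor, a higher number a weaker inhibitor), compound 1 gives 1700 nM. Compound 2 `O=C(CN1CCN(c2cccc(F)c2)CC1)Nc1nc2c(s1)CCCC2` shares much of its build but differs in its core and in the outer ring. In this assay compound 2 gives > 10000 nM, which is a limit of the measurement rather than a number. That reading is the limit of > 10000 nM in this assay, at which 1 of the 2 values shown sits. Compound 3 `O=C(CN1CCN(c2cccnc2)CC1)Nc1nc2c(s1)CCCC2` differs from compound 2 by pyridin-3-yl in place of 3-fluorophenyl on an amine nitrogen in a ring. Going by the values given here, no measured step covers this pair, so the expectation is uncertain. Compound 3 is expected to show a modest gain, a step of an at least 1.4-fold lower number from compound 2 to compound 3 (0.15 log units; that floor lies within the scatter). Compound 3 is estimated at 7000 nM, within a range from 2000 nM to 30000 nM.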

Compound 3, half-maximal inhibitory concentration: > 10000 nM
Compound 3 gave a limit, no number (the forecaster's own chance of this, stated with the estimate: 45%); middle value at least 1.4-fold (0.15 log units) from the limit.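

No step can be read from compound 2 to compound 3, since each gives only a limit rather than a number in this assay: the limit of > 10000 nM in this assay, at which 2 of the 3 values shown sit.

The compounds shown leave open whether pyridin-3-yl in place of 3-fluorophenyl changes inhibition at all.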